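Removing the Triazole Diol for a Dimethylamino Chain

The compounds below may be only part of what the source reports. "The series", "measured", "known", "first", "only" and "open" are said of these compounds alone.

Compound 1 `O=C1c2c[n+]([O-])c3ccccc3c2C(=O)c2c1c1ccccc1n2Cc1cn(CC(O)CO)nn1` carries the shared core with a 1-(2,3-dihydroxypropyl)-1H-1,2,3-triazol-4-yl group. In a functional assay on MDA-MB-231 cells (Homo sapiens) for cytotoxicity, read by MTT assay, with a stated time of 72 h (a higher number here means a weaker inhibitor, a lower number a stronger inhibitor), compound 1 gives 1290 nM, the highest of the two numbers in hand. Compound 3 `O=C1c2c[n+]([O-])c3ccccc3c2C(=O)c2c1c1ccccc1n2Cc1cn([C@H]2C[C@H](O)[C@@H](CO)O2)nn1` gives 580 nM in this assay, and the step of a 2.2-fold lower number from compound 1 to compound 3 (0.35 log units; beyond the scatter) is a modest gain. Compound 2 `CC1(C)OC[C@@H](Cn2cc(Cn3c4c(c5ccccc53)C(=O)c3c[n+]([O-])c5ccccc5c3C4=O)nn2)O1` returns only a limit in this assay, > 1000 nM. That limit is the limit of > 1000 nM in this assay, at which 1 of the 3 values shown sits, so the step that the limit leaves unreadable from compound 1 to compound 2 cannot be read, while the step of an at least 1.7-fold lower number from compound 2 to compound 3 (0.23 log units; that floor lies within the scatter) has a floor that stays within the scatter.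

Compound 4 `CN(C)CCCCn1c2c(c3ccccc31)C(=O)c1c[n+]([O-])c3ccccc3c1C2=O` differs from compound 1 in this way: 3-(dimethylamino)propyl in place of 1-(2,3-dihydroxypropyl)-1H-1,2,3-triazol-4-yl on a saturated chain carbon bound to an aromatic nitrogen. Within the data shown here, no measured step bears directly on this change; each of the measured steps alters only the group hung from the triazole, which compound 4 no longer carries. The one readable step, a 2.2-fold lower number from compound 1 to compound 3 (0.35 log units; beyond the scatter), was modest, and a change that removes the triazole altogether has no precedent among these compounds. The expected step is therefore a 1.4-fold lower number from compound 1 to compound 4 (0.16 log units; within the scatter), with wide uncertainty. Compound 4 is estimated at 900 nM, within 250 nM to 3500 nM.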

Compound 4, half-maximal inhibitory concentration: 350 nM
Estimate against measurement, compound 4: 2.6-fold (0.41 log units) above; low and high end bracket the measured number.
By their numbers in this assay, from the lowest: compounds 4 and 3 (each within the scatter of the next); then compound 1.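

Swapping the whole 1-(2,3-dihydroxypropyl)-1H-1,2,3-triazol-4-yl group for 3-(dimethylamino)propyl, on a saturated chain carbon bound to an aromatic nitrogen, gives in this assay a clear change: a 3.7-fold lower number from compound 1 to compound 4 (0.57 log units; beyond the scatter) is a modest gain beyond the scatter. The earlier compounds shown here varied only what hangs from the triazole, whereas compound 4 shows that this place tolerates losing the triazole and both hydroxyl groups, with a group that has no ring and no hydrogen-bond donors, without any loss in this assay. The values shown give no cause for this step.

The compounds shown leave open whether the gain follows from the terminal dimethylamino group, from the chain, or from losing the triazole. A triazole carrying a dimethylamino chain, an unsubstituted amine, a morpholine or a shorter or longer chain at this place would begin to separate these.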